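This account rests on a few compounds, and the source may have more. Where it says the series, first, only, none or still open, it means among the compounds named here.

Compound 1 `COc1ccccc1-c1cnc(NC(=O)c2ccc(F)cc2)n1C`: in a toxicity assay on THP-1 cells (Homo sapiens) for inhibition (a lower number here means that less compound is tolerated, a higher number that more compound is tolerated), compound 1 gives > 100000 nM, which is a limit and not a number.
Compound 2 `COc1ccc(-c2cnc(NC(=O)c3cccc(OC)c3)n2C)cc1`: in this assay compound 2 gives > 100000 nM, again only a limit.
Compound 3 `Cn1c(-c2ccccc2Cl)cnc1NC(=O)c1ccc(F)cc1`: in this assay compound 3 gives > 50000 nM, also a limit.

Compound 2 thus stands at a limit in this assay, with no number of its own. Two of the values shown sit at the limit of > 100000 nM in this assay, at which 2 of the 3 values shown sit, and one at the limit of > 50000 nM in this assay, at which 1 of the 3 values shown sits. Compound 4 `COc1ccc(-c2cnc(NC(=O)c3cccc(F)c3)n2C)cc1` differs from compound 2 by fluoro in place of methoxy on an aromatic carbon. Going by the values given here, the only one-place step measured, a step that the two limits leave unreadable from compound 1 to compound 3, is left unreadable by its two limits, so it gives neither size nor direction. With nothing read beyond the scatter, the expected step is a number no higher from compound 2 to compound 4 (the limit leaves the size open), none beyond scatter. Compound 4 is therefore estimated at 100000 nM in this assay, within 30000 nM to 300000 nM, most likely reported again as a limit.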

Compound 4, half-maximal cytotoxic concentration: > 100000 nM
Compound 4 was reported as a limit (the forecaster's own chance of this, stated with the estimate: 85%); the middle value sits exactly at the limit.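

Compound 2 and compound 4 both stand only at limits in this assay; the step between them, 3-methoxyphenyl to 3-fluorophenyl, cannot be read. The compounds shown leave open the concentration at which any of them reaches half-maximal cytotoxicity.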